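A few compounds are considered here, and "the series" means these few. Any claim that something is new, unique, unknown or untested is made for them only; others in the source may bear on it.

Of the compounds shown here, two have so far been measured in a functional assay on Huh-7 cells (Homo sapiens) for inhibition, read by sulforhodamine B assay, with a stated time of 72 h; on this read-out lower numbers stand for stronger inhibition and higher numbers for weaker inhibition. Compound 1 `COc1ccc(OC)c(C(=O)/C=C/c2cn(-c3ccccc3)nc2-c2cccnc2)c1` gives 1300 nM in this assay. Compound 2 `COc1ccc(C(=O)/C=C/c2cn(-c3ccccc3)nc2-c2ccncc2)cc1OC` gives 2000 nM in this assay; this is the highest of the two numbers, and its nearest neighbour is compound 1, whose number is lower by an amount that stays within the scatter, so the two compounds read as alike. Among the measured compounds shown here, compound 1 and compound 2 differ from each other in two places, and no single step between them is given.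

Compound 3 `COc1ccc(OC)c(C(=O)/C=C/c2cn(-c3ccccc3)nc2-c2ccncc2)c1` has not yet been measured. It differs from compound 2 by 2,5-dimethoxyphenyl in place of 3,4-dimethoxyphenyl on a carbonyl carbon. Compound 1 carries the same 2,5-dimethoxyphenyl group on its carbonyl carbon and gives 1300 nM in this assay, which is within the scatter of compound 2. On this basis the step from compound 2 to compound 3, estimated as a 1.4-fold lower number from compound 2 to compound 3 (0.15 log units; within the scatter), is expected to be small and not beyond the scatter, leaning if anything toward a lower number. Compound 3 is therefore estimated to give 1400 nM in this assay, with an expected range from 600 nM to 3200 nM.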

Compound 3, half-maximal inhibitory concentration: 1700 nM
Estimate against measurement, compound 3: 1.2-fold (0.08 log units) below, and the stated range covers the measured number.
By their numbers in this assay, from the lowest: compounds 1, 3 and 2 (each within the scatter of the next).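

With pyridin-4-yl held constant, 2,5-dimethoxyphenyl in place of 3,4-dimethoxyphenyl on a carbonyl carbon gives a 1.2-fold lower number from compound 2 to compound 3 (0.07 log units; within the scatter) in this assay, so this exchange can now be read as a single change and does not separate the two compounds. The second place can also be read on its own: with 2,5-dimethoxyphenyl held constant, pyridin-4-yl in place of pyridin-3-yl on an aromatic carbon gives a 1.3-fold higher number from compound 1 to compound 3 (0.12 log units; within the scatter). The two differences that lay together between compound 1 and compound 2 thus each stay within the scatter when taken singly, and the three compounds read as alike in this assay.

The compounds shown leave open whether a group of another kind on the carbonyl carbon, such as a phenyl ring carrying an amine or a carboxylic acid instead of the two methoxy groups, or pyridin-2-yl on the aromatic carbon, would shift the number beyond the scatter. No information is available that would explain how close these numbers lie.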